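Swapping One Triazole Isomer for Another on the Urea

A few compounds are considered here, and "the series" means these few. Any claim that something is new, unique, unknown or untested is made for them only; others in the source may bear on it.

Compound 3 `Cc1cc(C)c(NC(=O)N(Cc2ccc(-n3cncn3)cc2)C2CCCCCC2)c(C)c1` gives 26 nM in an assay on microsomes from intestine for inhibition of acyl-CoA:cholesterol acyltransferase (Oryctolagus cuniculus) (on this read-out higher numbers stand for weaker inhibition and lower numbers for stronger inhibition), the lowest number among the three measured compounds. Compound 1 `Cc1cc(C)c(NC(=O)N(Cc2ccc(-c3cccnc3)cc2)C2CCCCCC2)c(C)c1` gives 130 nM in this assay, and compound 2 `Cc1cc(C)c(NC(=O)N(Cc2ccc(-c3cn[nH]c3)cc2)C2CCCCCC2)c(C)c1` gives 270 nM. The step of a 5.0-fold lower number from compound 1 to compound 3 (0.70 log units; beyond the scatter) and the step of a 10-fold lower number from compound 2 to compound 3 (1.02 log units; beyond the scatter) both favour compound 3, whereas a 2.1-fold higher number from compound 1 to compound 2 (0.32 log units; beyond the scatter) runs the other way. Compound 4 `Cc1cc(C)c(NC(=O)N(Cc2ccc(-n3nccn3)cc2)C2CCCCCC2)c(C)c1` differs from compound 3 in one place: 2H-1,2,3-triazol-2-yl in place of 1H-1,2,4-triazol-1-yl on an aromatic carbon. The ring stays a five-membered aromatic ring with three hetero atoms, no donors and three acceptors, on an aromatic carbon para to a large group; only the arrangement of the nitrogens within the ring changes. For the measured compounds named here, no measured step exchanges one triazole for another, so the steps that bear on this change are only those that brought in the 1H-1,2,4-triazol-1-yl group, each beyond the scatter and modest to large. Because a 5.0-fold lower number from compound 1 to compound 3 (0.70 log units; beyond the scatter) and a 10-fold lower number from compound 2 to compound 3 (1.02 log units; beyond the scatter) both favour the triazole and compound 4 keeps a triazole of the same size, the expected step of a 1.3-fold higher number from compound 3 to compound 4 (0.13 log units; within the scatter) is small and may not reach beyond the scatter. Compound 4 is therefore expected to give 35 nM in this assay, with a range from 12 nM to 110 nM.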

Compound 4, half-maximal inhibitory concentration: 130 nM
Beside the measured number, compound 4's estimate is 3.7-fold (0.57 log units) below it, and the stated range ends below it.
By their numbers in this assay, from the lowest: compound 3; then compounds 1 and 4 (each within the scatter of the next); then compound 2.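

In this assay, the arrangement of the nitrogens alone matters at this position: with the same atoms and the same counts of donors and acceptors, placing 2H-1,2,3-triazol-2-yl where 1H-1,2,4-triazol-1-yl stood gives a 5.0-fold higher number from compound 3 to compound 4 (0.70 log units; beyond the scatter), so the advantage of compound 3 does not extend to triazoles as such. The new ring still compares well with 1H-pyrazol-4-yl, with a 2.1-fold lower number from compound 2 to compound 4 (0.32 log units; beyond the scatter), whereas against pyridin-3-yl it shows no change at the digits printed from compound 1 to compound 4 (within the scatter), so compound 1 and compound 4 cannot be told apart and compound 3 alone remains ahead of all the others. No measurement at hand accounts for the difference between the two triazole isomers.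

The compounds shown leave open where other five-membered rings on this aromatic carbon would fall, such as 1H-1,2,3-triazol-1-yl, imidazol-1-yl or tetrazol-1-yl, and so whether 1H-1,2,4-triazol-1-yl is a singular case. They also leave open whether the order among these rings would persist if an amine or a carboxylic acid were carried elsewhere on the shared core.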